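Adding a Methyl Group to a Second Sulfonamide Amide Core

The compounds below may be only part of what the source reports. "The series", "measured", "known", "first", "only" and "open" are said of these compounds alone.

The three compounds measured so far in a functional assay on MCF7 cells (Homo sapiens) for inhibition, read by MTT assay, with a stated time of 48 h (a higher number here means a weaker inhibitor, a lower number a stronger inhibitor), are:
compound 1, `O=C(Nc1cnn(-c2ccccc2)c1)c1cccc(NS(=O)(=O)c2ccc(Cl)cc2)c1`, 3130 nM
compound 2, `Cc1ccc(-n2cc(NC(=O)c3cccc(NS(=O)(=O)c4ccc(Cl)cc4)c3)cn2)cc1`, 1080 nM
compound 3, `O=C(Nc1cnn(-c2ccccc2)c1)c1ccc(NS(=O)(=O)c2ccccc2)cc1`, 17100 nM

Compounds 1 and 2 share one core and differ only by methyl in place of hydrogen on an aromatic carbon. That change gave a 2.9-fold lower number from compound 1 to compound 2 (0.46 log units; beyond the scatter). Compound 3 is built on a different core, and the difference between the two cores is not broken down here. Compound 3 stands highest of the three numbers, with compound 1 its nearest neighbour.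

Compound 4, `Cc1ccc(-n2cc(NC(=O)c3ccc(NS(=O)(=O)c4ccccc4)cc3)cn2)cc1`, has not yet been measured. It differs from compound 3 by methyl in place of hydrogen on an aromatic carbon. The place of this change is described in the same words as for the change from compound 1 to compound 2, so it is the same change carried onto a different core. For compound 4 the expected step is a 2.4-fold lower number from compound 3 to compound 4 (0.39 log units; beyond the scatter). This expectation rests on the earlier pair, because the same change gave a 2.9-fold lower number from compound 1 to compound 2 (0.46 log units; beyond the scatter), with some allowance since a change on another core need not repeat its size. Compound 4 is therefore estimated at 7000 nM in this assay, with a likely range from 3000 nM to 17000 nM.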

Compound 4, half-maximal inhibitory concentration: 10900 nM
Beside the measured number, compound 4's estimate is 1.6-fold (0.19 log units) below it; the measured number falls inside the stated range.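

In this assay, for the compounds shown here, the phenyl to 4-methylphenyl change on the core of compound 3 reads as a 1.6-fold lower number from compound 3 to compound 4 (0.20 log units; within the scatter) on its own, so on this core the methyl group gives no step that can be told apart from the ordinary spread of repeated measurements. Set beside the earlier pair, the two steps do not differ by more than that spread: the same change on two cores in this assay, a 2.9-fold lower number (0.46 log units; beyond the scatter) from compound 1 to compound 2 and a 1.6-fold lower number (0.20 log units; within the scatter) from compound 3 to compound 4, 1.8-fold (0.27 log units) apart, within the scatter of two such steps
Going by these compounds alone, this fits a change that carries from one core to the other at a similar size, but it does not prove that the size is the same, as it rests on only two pairs and one of the two steps is itself within the scatter.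

The compounds shown have only hydrogen or methyl at this place on the ring, so it stays open how a methoxy group, an amine or a carboxylic acid there would behave on either core. Within the data shown here, no single-change step links the two cores, so it is also open which part of the difference between them matters in this assay.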